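Expecting a Rise from Butyl to Thiophen-2-yl

This account rests on a few compounds, and the source may have more. Where it says the series, first, only, none or still open, it means among the compounds named here.

Compound 1 (`CC(C)(C)c1nc(-c2ccc[nH]2)c2cc(C(N)=O)c(N)nc2n1`) gives 130000 nM
Compound 2 (`CC(C)Cc1ncc2c(N)c(C#N)c(N)nc2n1`) gives 268000 nM
Compound 3 (`CCCCc1nc(C(C)(C)C)nc2nc(N)c(C#N)c(N)c12`) gives 6000 nM

In a physicochemical assay for solubility, in phosphate buffer, with a stated time of 18 h (a higher number here means a more soluble compound, a lower number a less soluble compound), compound 3 (6000 nM) stands lowest of the three, clearly beyond the usual scatter. Compound 1 is nearest and compound 2 furthest. Compound 4 (`CC(C)(C)c1nc(-c2cccs2)c2c(N)c(C#N)c(N)nc2n1`) is still unmeasured. It carries thiophen-2-yl in place of butyl on an aromatic carbon. Among the compounds with values here, no measured pair differs in just one place, so direct evidence is lacking. Compound 1 (130000 nM) also bears a five-membered aromatic ring, though it differs elsewhere too. The expected change (a 3.7-fold higher number from compound 3 to compound 4 (0.56 log units; beyond the scatter)) is a moderate rise in this assay and probably lies beyond the scatter. For compound 4 the estimated value is 22000 nM (expected range 5000 nM to 90000 nM).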

Compound 4, solubility: 56000 nM
The estimate for compound 4 lay 2.5-fold (0.41 log units) below the measured number; the measured number falls inside the stated range.
By their numbers in this assay, from the lowest: compound 3; then compound 4; then compound 1; then compound 2.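

Within the data shown here, putting thiophen-2-yl in place of butyl on an aromatic carbon gives a 9.3-fold higher number from compound 3 to compound 4 (0.97 log units; beyond the scatter) in this assay and provides the first comparison in which only one place changes. It shows that the group at this carbon, next to the ring nitrogen, can move the number beyond the usual scatter on this shared core. The compounds shown leave open whether a phenyl ring or a longer chain at this carbon would give a similar number, and whether the step would hold on another core. No measurement in hand explains this rise.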